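Configuration at the ring stereocentre in the ether series

The source may report more compounds than this note shows. Statements on the series, on what has been measured and on what is new or still open speak of the compounds shown alone.

Three compounds have numbers in an assay on membranes from HEK293 cells for displacement of a labelled ligand from Sigma intracellular receptor 2 (Homo sapiens); a lower number here means a stronger inhibitor, a higher number a weaker inhibitor. Compound 1 `COc1ccc(CN2CCC[C@@H](OCc3ccc(F)c(C)c3)C2)cc1F` gives 206 nM in this assay, the highest of the three numbers. Compound 2 `Cc1c(Cl)cccc1NC(=O)CN1CCC2(CCCN2Cc2ccc(F)c(F)c2)CC1` gives 121 nM in this assay, and that number sits within the scatter of the number for compound 1. Within the data shown here, compound 3 `FC(F)(F)c1cccc(COC2CCN(Cc3ccc4[nH]cnc4c3)CC2)c1` gives 73 nM in this assay, and here the gap to compound 1 lies beyond the scatter, so compound 3 is the one member with a clearly lower number. Among the measured compounds shown here, no pair among the three differs in only one place, so no single step has been measured.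

Compound 4 `COc1ccc(CN2CCC[C@H](OCc3ccc(F)c(C)c3)C2)cc1F` has not been measured in this assay. Its relation to compound 1 is the two compounds have the same atoms and bonds and differ only in configuration as drawn: 1 of 1 stereo elements differ; a stereocentre at a saturated ring carbon is drawn R in compound 1 and S in compound 4; in words, the two compounds have the same atoms and bonds and differ only in configuration as drawn, one stereo element differing, a stereocentre at a saturated ring carbon drawn R in compound 1 and S in compound 4. Nothing in the measured set shows how this assay responds to such a change, so the direction is open and no step beyond the scatter is expected with confidence, while a wide range must be allowed. Compound 4 is estimated at 160 nM in this assay, with a range from 40 nM to 700 nM, which means an expected step of a 1.3-fold lower number from compound 1 to compound 4 (0.11 log units; within the scatter).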

Compound 4, inhibition constant: 123 nM
Compound 4: the middle estimate sits 1.3-fold (0.11 log units) above what was measured; the measured number falls inside the stated range.
By their numbers in this assay, from the lowest: compounds 3, 2, 4 and 1 (each within the scatter of the next, the first and the last beyond it).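

The series now has its first single-place step in this assay, and it sits at the stereocentre at a saturated ring carbon: going from the R to the S drawing gives a 1.7-fold lower number from compound 1 to compound 4 (0.22 log units; within the scatter). With everything else held fixed, the configuration at this position does not separate the pair beyond the scatter, so neither drawing shows a clear preference in this assay, at least with this ether and this pair of aromatic substituents. The step can be read on the stereocentre alone, since no other part of the structure changes: the fact that compounds 1 and 4 differ only in the configuration as drawn

The compounds shown leave open how this assay responds to a change of the group on the stereocentre itself, for example an amine or a carboxylic acid in place of the ether oxygen. Also open, on these data alone, is whether the two configurations would stay within the scatter of each other with such a group, or with a longer chain in place of the ether link.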